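Acetyl(methyl)amino replaces propylamino on compound 2

A few compounds are considered here, and "the series" means these few. Any claim that something is new, unique, unknown or untested is made for them only; others in the source may bear on it.

In a functional assay on the whole organism with Rattus norvegicus as the target (a lower number here means that less compound is needed, a higher number that more compound is needed for the effect), compound 1 `COc1cc(N)c(Cl)cc1C(=O)NCCN(C)Cc1ccccc1C(F)(F)F` gives 30 mg/kg and compound 2 `CCCNc1cc(OC)c(C(=O)NC2CCN(Cc3ccccc3)C2)cc1Cl` gives 17 mg/kg so these two numbers lie within the usual scatter of each other. Compound 3 `COc1cc(N(C)C(C)=O)c(Cl)cc1C(=O)NC1CCN(Cc2ccccc2)C1` carries acetyl(methyl)amino in place of the propylamino of compound 2 on an aromatic carbon acetyl(methyl)amino in place of propylamino on an aromatic carbon and is otherwise the same. Among the compounds with values here, no measured pair of compounds shows this swap, so the expected move a 1.5-fold higher number from compound 2 to compound 3 (0.17 log units; within the scatter) is small, towards a higher number, and uncertain. In this assay compound 3 is estimated at 25 mg/kg with a likely range from 7 mg/kg to 90 mg/kg until it is measured.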

Compound 3, dose for half-maximal effect: > 30 mg/kg
Compound 3 gave a limit, no number; the forecaster's own chance of this, stated with the estimate: 20%; at least 1.2-fold (0.07 log units) between middle value and limit.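

In this assay compound 3 gives only a limit, > 30 mg/kg, not a number. Within the data shown here, replacing propylamino with acetyl(methyl)amino gives the first direct comparison at this position, an at least 1.7-fold higher number from compound 2 to compound 3 (0.24 log units; that floor lies within the scatter), so the swap brings no lower number, yet this floor alone does not establish a real loss. The step is only a floor because the read-out ends at a limit: the limit of > 30 mg/kg in this assay, at which 1 of the 3 values shown sits.

From the compounds shown here alone, the true size of the step stays open. Also open, going by these compounds, is how methylamino or butylamino, each keeping a hydrogen-bond donor on this aromatic carbon, would read.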